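The compounds below may be only part of what the source reports. "The series", "measured", "known", "first", "only" and "open" are said of these compounds alone.

Measured compounds:
compound 1 `Cc1cc(C(=O)O)ccc1OCCCCOc1ccc(C(=O)CC(C)C)c(O)c1C` — 42.1%
compound 2 `COC(=O)c1ccc(OCCCCOc2ccc(C(=O)CC3CCCC3)c(O)c2C)cc1` — 22%

In an assay on HEK293 cells for positive allosteric modulation of metabotropic glutamate receptor 3 (Rattus norvegicus), read by thallium flux, with a stated time of 2.5 min (a lower number here means a smaller maximal response, a higher number a larger maximal response), compound 2 gives 22%, the lowest of the two numbers; compound 1 stands higher by a gap beyond the usual scatter. Compound 3 `Cc1c(OCCCCOc2ccc(C(=O)O)cc2F)ccc(C(=O)CC2CCCC2)c1O` is not yet measured. It differs from compound 2 in one place: 4-carboxy-2-fluorophenyl in place of 4-(methoxycarbonyl)phenyl on an oxygen on a saturated carbon. Compound 1 carries a free carboxylic acid and gives 42.1%, so a rise is expected for the step of a number 14 percentage points higher from compound 2 to compound 3 (beyond the scatter), of a size beyond the scatter. Compound 3 is estimated at 36%, with a range from 20% to 55%.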

Compound 3, largest response reached (reported as percent of maximum), in percent of the reference or control that the assay uses: 31.2%
The estimate for compound 3 lay 4.8 percentage points above the measured number, and the stated range covers the measured number.
By their numbers in this assay, from the lowest: compounds 2 and 3 (each within the scatter of the next); then compound 1.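

In this assay, putting 4-carboxy-2-fluorophenyl in place of 4-(methoxycarbonyl)phenyl gives a number 9.2 percentage points higher from compound 2 to compound 3 (within the scatter), a step within the usual scatter. On this oxygen-linked chain, then, the ester can give way to a free carboxylic acid plus a fluorine with no change that can be told from scatter. Nothing measured here offers an explanation for this result. On these data alone, the acid and the fluorine enter together, so the share of each stays unknown, and 4-carboxyphenyl without fluorine would separate them. As far as these compounds go, how a primary amide or a tetrazole would behave at this place also stays open.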